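Swapping Fluoro for Chloro in a Clearance Series

A few compounds are considered here, and "the series" means these few. Any claim that something is new, unique, unknown or untested is made for them only; others in the source may bear on it.

Measured so far in an in vitro ADME assay on microsomes from liver (Homo sapiens) for pharmacokinetics, read by LC-MS, with a stated time of 10 min, tested at 1 uM; on this read-out higher numbers stand for fast clearance and lower numbers for slow clearance
- compound 1 `CN1C[C@H](C(=O)Nc2ccccc2)[C@@H](c2ccc(/C=C/C(=O)Nc3ccccc3N)cc2)C1` gives 7 mL/min/kg
- compound 2 `CN1C[C@H](C(=O)Nc2cccc(F)c2)[C@@H](c2ccc(/C=C/C(=O)Nc3ccccc3N)cc2)C1` gives 6 mL/min/kg

Compound 2 stands level with compound 1 on these numbers, and the two values lie within the scatter of each other. Compound 3 `CN1C[C@H](C(=O)Nc2cccc(Cl)c2)[C@@H](c2ccc(/C=C/C(=O)Nc3ccccc3N)cc2)C1` has not yet been measured. It differs from compound 2 by chloro in place of fluoro on an aromatic carbon and this places chloro in place of fluoro on an aromatic carbon, meta to a large group. Among the measured compounds shown here, no measured step covers this exact swap. The nearest evidence is fluoro in place of hydrogen on an aromatic carbon, which is a 1.2-fold lower number from compound 1 to compound 2 (0.07 log units; within the scatter) and thus shows no change in this assay beyond the scatter. On that basis the expected step is a 1.2-fold higher number from compound 2 to compound 3 (0.07 log units; within the scatter) and no shift beyond the scatter is anticipated. For compound 3 the estimated clearance is 7 mL/min/kg (expected range 4 mL/min/kg to 13 mL/min/kg).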

Compound 3, clearance: 7 mL/min/kg
Compound 3: the middle estimate sits on the measured number at the digits printed; low and high end bracket the measured number.
By their numbers in this assay, from the lowest: compounds 2, 1 and 3 (each within the scatter of the next).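

In this assay, chloro on this aromatic carbon, meta to a large group, reads much like fluoro, with a 1.2-fold higher number from compound 2 to compound 3 (0.07 log units; within the scatter) for the swap. Among the compounds shown here, measured against hydrogen in the same place, chloro gives no change at the digits printed from compound 1 to compound 3 (within the scatter) and so adds a second halogen to the one the earlier compounds covered, with neither one moving the clearance beyond the scatter. Nothing on hand offers a reason for this flat response.

The compounds shown leave open whether the 3-chlorophenyl result extends to other kinds of group at this position, such as methoxy, trifluoromethyl or an amine. They also leave open whether any group placed elsewhere on the same ring, or on the rest of the shared core, would move the clearance beyond the scatter.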